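Removing one methoxy group: from compound 2 to compound 4

The compounds below may be only part of what the source reports. "The series", "measured", "known", "first", "only" and "open" are said of these compounds alone.

Measured so far in a functional assay on NCI-H522 cells (Homo sapiens) for cytotoxicity, read by sulforhodamine B assay, with a stated time of 48 h, tested at 100 uM; a higher number here means a weaker effect of the compound at the concentration tested, a lower number a stronger effect:
compound 1 `COc1ccc(-c2cc(/C=C/C(=O)c3ccc(N)cc3)[nH]n2)cc1` gives -75%;
compound 2 `COc1cc(-c2cc(/C=C/C(=O)c3ccc(N)cc3)[nH]n2)cc(OC)c1OC` gives -83%;
compound 3 `COc1ccc(C(=O)/C=C/c2cc(-c3cc(OC)c(OC)c(OC)c3)n[nH]2)cc1OC` gives -97%.

Compound 2 stands second highest of the three numbers. Compound 1 lies within the scatter of it, while compound 3 lies beyond, with a change of a number 14 percentage points lower from compound 2 to compound 3 (beyond the scatter) from a different alteration, the carbonyl-side group. Compound 4 `COc1ccc(-c2cc(/C=C/C(=O)c3ccc(N)cc3)[nH]n2)cc1OC` differs from compound 2 by hydrogen in place of methoxy on an aromatic carbon. Among the measured compounds shown here, no measured step changes a methoxy group, so only the values of compounds 1 and 2, which carry one and three methoxy groups on that ring and sit within the scatter of each other, bear on it. In this assay compound 4 is therefore expected to give about -80%, ranging from -95% to -65%. The expected step of a number 3 percentage points higher from compound 2 to compound 4 (within the scatter) is estimated to stay within the scatter.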

Compound 4, a percentage reported as activity, at one concentration (the size of the read-out at that concentration, not a potency): -92%
The estimate for compound 4 lay 12 percentage points above the measured number; the measured number falls inside the stated range.
By their numbers in this assay, from the lowest: compounds 3, 4, 2 and 1 (each within the scatter of the next, the first and the last beyond it).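

In this assay, a methoxy group in place of hydrogen on this aromatic carbon gives a number 17 percentage points lower from compound 1 to compound 4 (beyond the scatter), the first sign that a second methoxy group on this ring can matter. Hydrogen in place of methoxy at the other end of the series gives a number 9 percentage points lower from compound 2 to compound 4 (within the scatter), so a third methoxy group adds nothing that can be told from scatter. No evidence is available on why these steps differ in this way.

From the compounds shown here alone, whether a hydroxyl group or a chlorine atom on this carbon would act like methoxy remains open. So does whether the pattern holds with the carbonyl-side group of compound 3.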